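The source may report more compounds than this note shows. Statements on the series, on what has been measured and on what is new or still open speak of the compounds shown alone.

Of the compounds shown here, three built on one shared core have been measured in an assay on CHO-K1 cells for displacement of a labelled ligand from prostaglandin E2 receptor EP1 subtype (Homo sapiens); a lower number here means a stronger inhibitor, a higher number a weaker inhibitor. Compound 1 `Cc1cc(C(=O)Nc2ccc(F)cc2)nn1Cc1cc(Cl)ccc1OCc1ccccc1` gives 79.4 nM, the highest number among the three and therefore the weakest inhibitor shown. Compound 2 `Cc1cc(NC(=O)C(C)C)nn1Cc1cc(Cl)ccc1OCc1ccccc1` gives 25.1 nM, and compound 3 `Cc1cc(NC(=O)c2ccccc2)nn1Cc1cc(Cl)ccc1OCc1ccccc1` gives 15.9 nM. The two steps away from compound 1 both lower the number: a 3.2-fold lower number from compound 1 to compound 2 (0.50 log units; beyond the scatter) and a 5.0-fold lower number from compound 1 to compound 3 (0.70 log units; beyond the scatter). Between the two nearer compounds the difference is small, a 1.6-fold lower number from compound 2 to compound 3 (0.20 log units; within the scatter).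

Compound 4 `Cc1cc(NC(=O)OCc2ccccc2)nn1Cc1cc(Cl)ccc1OCc1ccccc1` is the next candidate. Compared with compound 1 the change is (benzyloxycarbonyl)amino in place of (4-fluorophenyl)carbamoyl on an aromatic carbon. As in compound 2 and compound 3, the group now carries its nitrogen on the ring and its carbonyl beyond it, so those two steps are the relevant ones. Going by the values given here, both were modest and both pointed downward, and they are the only guide available, since no carbamate of this kind has been measured here.

The expectation for compound 4 is therefore a modest lowering, a 3.6-fold lower number from compound 1 to compound 4 (0.56 log units; beyond the scatter), placing it near compound 2 and compound 3 rather than compound 1. The estimated value for compound 4 is 22 nM, with a plausible range from 8 nM to 60 nM.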

Compound 4, half-maximal inhibitory concentration: 79.4 nM
Beside the measured number, compound 4's estimate is 3.6-fold (0.56 log units) below it; measured number above the stated range.
By their numbers in this assay, from the lowest: compounds 3 and 2 (each within the scatter of the next); then compounds 1 and 4 (each within the scatter of the next).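

Having the nitrogen on the ring and the carbonyl beyond it does not by itself bring the lower numbers in this assay at this position: (benzyloxycarbonyl)amino gives no change at the digits printed from compound 1 to compound 4 (within the scatter) even though it is attached the same way round as the groups in compound 2 and compound 3. What separates compound 4 from those two is the part on the far side of the carbonyl, where benzyloxy in place of phenyl gives a 5.0-fold higher number from compound 3 to compound 4 (0.70 log units; beyond the scatter) and benzyloxy in place of isopropyl gives a 3.2-fold higher number from compound 2 to compound 4 (0.50 log units; beyond the scatter) in this small set, so the group on the carbonyl counts as well as the direction of the link. No measurement shown here accounts for this difference.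

The compounds shown leave open whether the oxygen of the benzyloxy group or its greater length is what matters, a question that a benzyl group placed directly on the carbonyl would help to separate. They also leave open whether a urea, with a nitrogen in place of that oxygen, would fall with compound 4 or with compound 2 and compound 3.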